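Emax in the F508del series: compound 3 to compound 4

The source may report more compounds than this note shows. Statements on the series, on what has been measured and on what is new or still open speak of the compounds shown alone.

Measured compounds:
Compound 1, `COc1ncc(C(F)(F)F)cc1CO[C@H]1[C@H](C(C)(C)C)[C@@H](C(=O)O)N(C(=O)[C@@H]2CCCCO2)[C@H]1c1ccccc1C1CC1`: 610%
Compound 2, `COc1ncc(C(F)(F)F)cc1CO[C@H]1[C@H](C(C)(C)C)[C@@H](C(=O)O)N(C(=O)[C@@H]2CCCCO2)[C@H]1c1ccccc1Cl`: 694%
Compound 3, `CCc1ccccc1[C@H]1[C@@H](OCc2cc(C(F)(F)F)cnc2OC)[C@H](C(C)(C)C)[C@@H](C(=O)O)N1C(=O)[C@@H]1CCCCO1`: 490%

In an assay on cells with Cystic fibrosis transmembrane conductance regulator variant F508del (Homo sapiens) as the target, read by voltage clamp, with a stated time of 24 h, in the presence of a further agent that is not named here (a lower number here means a smaller maximal response, a higher number a larger maximal response), compound 3 holds the lowest of the three numbers. Its nearest neighbour is compound 1, with the step of a number 120 percentage points lower from compound 1 to compound 3 (beyond the scatter); the step to compound 2 is larger, a number 204 percentage points lower from compound 2 to compound 3 (beyond the scatter). Both steps replace a group on the aromatic carbon of the shared core, and both reach the same ethyl-bearing compound 3.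

Compound 4, `COc1ncc(C(F)(F)F)cc1CO[C@H]1[C@H](C(C)(C)C)[C@@H](C(=O)O)N(C(=O)[C@@H]2CCCCO2)[C@H]1c1ccccc1CC(C)C`, has not yet been measured in this assay. It differs from compound 3 by isopropyl in place of methyl on a saturated chain carbon bound to an aromatic carbon. Among the measured compounds shown here, no measured pair shows a change of this kind, a growth of an alkyl chain on the same aromatic carbon; the two steps that do bear on it, a number 120 percentage points lower from compound 1 to compound 3 (beyond the scatter) and a number 204 percentage points lower from compound 2 to compound 3 (beyond the scatter), only show that the ethyl compound 3 sits below the chloro and cyclopropyl compounds. For compound 4 the step of a number 40 percentage points lower from compound 3 to compound 4 (beyond the scatter) is therefore expected to be small, within or close to the scatter, with the wider uncertainty on the lower side. Compound 4 is estimated at 450%, with a range of 300% to 620%.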

Compound 4, largest response reached (Emax), in percent of the reference or control that the assay uses: 472%
Compound 4: middle estimate off by 22 percentage points, on the low side; measured number inside the range.
By their numbers in this assay, from the lowest: compound 4; then compound 3; then compound 1; then compound 2.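

In this assay, ethyl to isobutyl on the aromatic carbon gives a beyond-scatter but modest step (a number 18 percentage points lower from compound 3 to compound 4 (beyond the scatter)), the first change shown between two open-chain alkyl groups at this position. The steps from the other two groups are much larger (a number 222 percentage points lower from compound 2 to compound 4 (beyond the scatter) and a number 138 percentage points lower from compound 1 to compound 4 (beyond the scatter)), and among these four compounds, the ethyl and isobutyl compounds both fall below the chloro and cyclopropyl compounds, with none going against this order. Nothing available here accounts for these differences.

As far as these compounds go, it remains open whether a longer open chain on the same aromatic carbon would continue the small downward step from compound 3 to compound 4. A methoxy group, an amine or a bromine there could fall anywhere relative to compound 2.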